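A Ring Nitrogen Swap on a Kinase-Style Scaffold

A few compounds are considered here, and "the series" means these few. Any claim that something is new, unique, unknown or untested is made for them only; others in the source may bear on it.

Compound 1 `Cn1c(=O)c(S(=O)(=O)c2ccc(F)cc2F)cc2cnc(Nc3ccc4cc[nH]c4c3)nc21`: 5000 nM
Compound 2 `Cn1c(=O)c(S(=O)(=O)c2ccccc2)cc2cnc(Nc3ccc4cc[nH]c4c3)nc21`: 10000 nM
Compound 3 `Cn1c(=O)c(S(=O)(=O)c2ccc(F)cc2)cc2cnc(Nc3ccc4cc[nH]c4c3)nc21`: 10000 nM

Three compounds share one core and differ only in the ring attached to the sulfonyl sulfur. In a functional assay on DU-145 cells (Homo sapiens) for inhibition, read by trypan blue exclusion, with a stated time of 72 h (a higher number here means a weaker inhibitor, a lower number a stronger inhibitor), compound 1 gives 5000 nM, the lowest of the three numbers, yet the steps of a 2.0-fold higher number from compound 1 to compound 2 (0.30 log units; within the scatter) and a 2.0-fold higher number from compound 1 to compound 3 (0.30 log units; within the scatter) are both within the scatter, so compound 1 cannot be called stronger than compound 2 or compound 3. Between those two there is no change at the digits printed from compound 2 to compound 3 (within the scatter).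

Compound 4 `Cn1c(=O)c(S(=O)(=O)c2ccc(F)cc2F)cc2cnc(Nc3cnc4[nH]ccc4c3)nc21` keeps the 2,4-difluorophenyl of compound 1 and changes the other end of the molecule instead: a group of 9 heavy atoms (7 carbon, 2 nitrogen; one five-membered aromatic ring with 1 hetero atom, one six-membered aromatic ring with 1 hetero atom) in place of a group of 9 heavy atoms (8 carbon, 1 nitrogen; one five-membered aromatic ring with 1 hetero atom, one six-membered aromatic ring of carbon only), on a nitrogen on an aromatic ring. Within the data shown here, no measured step touches this part of the molecule; every step so far concerned the sulfonyl ring and stayed within the scatter. The data therefore give no reason to expect movement in this assay beyond the scatter in either direction, and the estimate rests on the position of compound 1.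

Compound 4 is expected to give 5000 nM in this assay, within a range from 1500 nM to 15000 nM, which means an expected step of no change at the digits printed from compound 1 to compound 4 (within the scatter).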

Compound 4, half-maximal inhibitory concentration: 750 nM
Compound 4: middle estimate off by 6.7-fold (0.82 log units), on the high side; measured number outside the range, below it.
By their numbers in this assay, from the lowest: compound 4; then compounds 1, 2 and 3 (each within the scatter of the next).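

The earlier compounds shown here varied only the ring on the sulfonyl sulfur, and none of their steps left the scatter, so they said nothing about the other end of the molecule. With the 2,4-difluorophenyl held fixed, the step of a 6.7-fold lower number from compound 1 to compound 4 (0.82 log units; beyond the scatter) in this assay shows that this other end, the group on a nitrogen on an aromatic ring, can move the number, even though the change is slight: the entering group has a nitrogen in its six-membered aromatic ring where 1H-indol-6-yl has only carbon, and it counts a hydrogen-bond acceptor that 1H-indol-6-yl lacks. Nothing available shows how this swap lowers the number, so the step stands as an observation without an explanation.

Whether the same swap would lower the number with the sulfonyl rings of compound 2 and compound 3 stays open, since only the pair carrying 2,4-difluorophenyl is shown. Also open, as far as these compounds go, is what other groups on this nitrogen would do, for example an open-chain amine or a carboxylic acid in place of 1H-indol-6-yl.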